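Cyano to acetyl in a series held at the limit

The source may report more compounds than this note shows. Statements on the series, on what has been measured and on what is new or still open speak of the compounds shown alone.

Values in a functional assay on Jurkat cells (Homo sapiens) for cytotoxicity, with a stated time of 72 h (a lower number here means that less compound is needed, a higher number that more compound is needed for the effect), each one a limit and not a number:
- compound 1 `C=C[C@@](C)(/C=C/c1ccc(OS(=O)(=O)C(F)(F)F)cc1)CCC=C(C)C` gives > 49000 nM (limit)
- compound 2 `C=C[C@@](C)(/C=C/c1ccc(O)c(/C=C/C#N)c1)CCC=C(C)C` gives > 49000 nM (limit)
- compound 3 `COc1ccc(/C=C/[C@@](C)(/C=C/c2ccc(O)c(/C=C/C#N)c2)CCC=C(C)C)cc1` gives > 49000 nM (limit)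

In this assay compound 3 gives > 49000 nM as a limit. All the measured compounds share one reading (the limit of > 49000 nM in this assay, at which 3 of the 3 values shown sit). Compound 4 `COc1ccc(/C=C/[C@@](C)(/C=C/c2ccc(O)c(/C=C/C(C)=O)c2)CCC=C(C)C)cc1` carries acetyl in place of cyano on a double-bonded chain carbon bound to a double-bonded chain carbon. Among the measured compounds shown here, the only measured step (a step that the two limits leave unreadable from compound 2 to compound 3) lies elsewhere in the structure and gives no readable size, so no measured step bears on this change. Compound 4 may well stay at the limit, and any expected step (an at least 1.4-fold lower number from compound 3 to compound 4 (0.14 log units; that floor lies within the scatter)) toward a lower number is a weak expectation. For compound 4 the estimate is 35000 nM with an expected range (8000 nM to 60000 nM).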

Compound 4, half-maximal effective concentration: > 49000 nM
Compound 4: only a limit was reported; the forecaster's own chance of this, stated with the estimate: 55%; middle value at least 1.4-fold (0.14 log units) away from the limit.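

Compound 3 and compound 4 are both reported only as limits in this assay, and no step can be read between them. The compounds shown leave open whether acetyl in place of cyano changes this read-out at all.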